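Nitro kept, sulfur for oxygen, methyl added

The source may report more compounds than this note shows. Statements on the series, on what has been measured and on what is new or still open speak of the compounds shown alone.

Compound 1 `CSc1ccccc1OC(C)(C)C1OCC(C/C=C\CCC(=O)O)C(c2cccnc2)O1` gives 36 nM in an assay for inhibition of Thromboxane-A synthase (Homo sapiens), using microsomes; on this read-out lower numbers stand for stronger inhibition and higher numbers for weaker inhibition. Compound 2 `CC(C)(Oc1ccccc1[N+](=O)[O-])C1OCC(C/C=C\CCC(=O)O)C(c2cccnc2)O1` reaches only the limit of this assay, < 10 nM. Among the compounds with values here, the single measured step, an at least 3.6-fold lower number from compound 1 to compound 2 (0.55 log units; beyond the scatter), is bounded by the limit of < 10 nM in this assay, at which 1 of the 2 values shown sits, so compound 2 stands at a limit and not at a number. Compound 3 `Cc1ccc(SC(C)(C)C2OCC(C/C=C\CCC(=O)O)C(c3cccnc3)O2)c([N+](=O)[O-])c1` differs from compound 2 by a group of 11 heavy atoms (7 carbon, 1 nitrogen, 2 oxygen, 1 sulfur; one six-membered aromatic ring of carbon only) in place of a group of 10 heavy atoms (6 carbon, 1 nitrogen, 3 oxygen; one six-membered aromatic ring of carbon only), on a saturated chain carbon bound to two saturated chain carbons and a saturated ring carbon. Within the data shown here, no measured step covers the sulfur for oxygen exchange or the added methyl; the nitro group of the measured step remains. For compound 3 the expected step is a number no lower from compound 2 to compound 3 (the limit leaves the size open) in this assay. Compound 3 is therefore estimated at 10 nM, between 3 nM and 40 nM.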

Compound 3, half-maximal inhibitory concentration: 30 nM
Beside the measured number, compound 3's estimate is 3.0-fold (0.48 log units) below it, within the range that was stated.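

On the saturated chain carbon, the group carrying sulfur and the added methyl in place of 2-nitrophenoxy gives an at least 3.0-fold higher number from compound 2 to compound 3 (0.47 log units; beyond the scatter). Compound 2 stands at a limit: the limit of < 10 nM in this assay, at which 1 of the 3 values shown sits. Replacing the group of compound 1 with that same group gives a 1.2-fold lower number from compound 1 to compound 3 (0.08 log units; within the scatter), so the presence of a nitro group does not by itself give a value like that of compound 2.

Sulfur and the added methyl enter together here, leaving their separate contributions open. From the compounds shown here alone, how an amine in place of the nitro group would read also stays open.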